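The compounds below may be only part of what the source reports. "The series", "measured", "known", "first", "only" and "open" are said of these compounds alone.

Among the compounds with values here, compound 2 `COc1ccc(F)c(-c2ccc(Cc3ccc(N4CCC[C@H]4CC(=O)O)cc3)c(C)c2)c1` is one of only two compounds measured in a functional assay on cells for agonist activity at Free fatty acid receptor 1 (Homo sapiens), read by FLIPR and calcium flux, with a stated time of 100 s; on this read-out lower numbers stand for an effect already at smaller amounts and higher numbers for an effect only at larger amounts of compound: compound 2 gives 220 nM, and compound 1 `Cc1ccccc1Cc1ccc(N2CCC[C@H]2CC(=O)O)cc1` gives 150 nM, with the single step, a 1.5-fold higher number from compound 1 to compound 2 (0.17 log units; within the scatter), lying within the scatter, so the two numbers cannot be ordered. Compound 3 `COc1ccc(F)c(-c2ccc(Cc3ccc(N4C[C@H](C(F)(F)F)C[C@H]4CC(=O)O)cc3)c(C)c2)c1` differs from compound 2 by trifluoromethyl in place of hydrogen on a saturated ring carbon. No measured step touches a saturated ring carbon of the core, so nothing shown points to a shift in this assay beyond the scatter in either direction. Compound 3 is therefore expected near 250 nM, with an estimated range of 90 nM to 700 nM. The expected step is a 1.1-fold higher number from compound 2 to compound 3 (0.06 log units; within the scatter).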

Compound 3, half-maximal effective concentration: 1700 nM
Compound 3: the middle estimate sits 6.8-fold (0.83 log units) below what was measured, outside the stated range (above it).
By their numbers in this assay, from the lowest: compounds 1 and 2 (each within the scatter of the next); then compound 3.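

In this assay, trifluoromethyl in place of hydrogen on this saturated ring carbon gives a 7.7-fold higher number from compound 2 to compound 3 (0.89 log units; beyond the scatter) and is the only step shown beyond the scatter. Within the data shown here, the earlier aromatic-carbon change, a 1.5-fold higher number from compound 1 to compound 2 (0.17 log units; within the scatter), stays within the scatter, so only this step shows that a change on the saturated ring carbon can move the number. Nothing measured here bears on the reason for the shift.

On these data alone, whether methyl, a single fluorine or a hydroxyl group at this carbon gives a comparable step remains open. Also open, as far as these compounds go, is how trifluoromethyl behaves with the opposite configuration at this carbon.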